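Hydroxyphenyl in Place of Methoxyphenyl on a Sulfonamide Benzoic Acid

The source may hold more compounds than are shown below. What is called first, only, known or untested is meant among the compounds shown, and "the series" means these compounds.

Measured so far in an assay on mitochondria (strain BALB/c) for inhibition of glycerol-3-phosphate acyltransferase 1, mitochondrial (Mus musculus), read by scintillation counting, with a stated time of 10 min; on this read-out higher numbers stand for weaker inhibition and lower numbers for stronger inhibition:
compound 1 `CCCCCCCCS(=O)(=O)Nc1cc(-c2ccccc2Cl)ccc1C(=O)O` gives 26900 nM
compound 2 `CCCCCCCCS(=O)(=O)Nc1cc(-c2ccc(-c3ccccc3)cc2)ccc1C(=O)O` gives 13500 nM
compound 3 `CCCCCCCCS(=O)(=O)Nc1cc(-c2ccccc2OC)ccc1C(=O)O` gives 16100 nM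

Compound 3 stands second highest of the three numbers; its gaps to compound 2 and to compound 1 both lie within the scatter. Compound 4 `CCCCCCCCS(=O)(=O)Nc1cc(-c2ccc(O)cc2)ccc1C(=O)O` differs from compound 3 by 4-hydroxyphenyl in place of 2-methoxyphenyl on an aromatic carbon. Among the compounds with values here, the only measured step that touches this part of the molecule is a 1.7-fold lower number from compound 1 to compound 3 (0.22 log units; within the scatter), which stays within the scatter. Within the data shown here, no measured compound carries a hydroxy group, so the step of a 1.1-fold higher number from compound 3 to compound 4 (0.05 log units; within the scatter) is expected to stay within the scatter as well. Compound 4 is therefore estimated at 18000 nM in this assay, with a range from 7000 nM to 45000 nM.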

Compound 4, half-maximal inhibitory concentration: 64800 nM
Beside the measured number, compound 4's estimate is 3.6-fold (0.56 log units) below it; measured number above the stated range.
By their numbers in this assay, from the lowest: compounds 2, 3 and 1 (each within the scatter of the next); then compound 4.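

In this assay, within the data shown here, 4-hydroxyphenyl is the first group at this aromatic carbon to give a step beyond the scatter, with a 4.0-fold higher number from compound 3 to compound 4 (0.60 log units; beyond the scatter). The other two comparisons point the same way, with a 4.8-fold higher number from compound 2 to compound 4 (0.68 log units; beyond the scatter) and a 2.4-fold higher number from compound 1 to compound 4 (0.38 log units; beyond the scatter), which makes compound 4 the weakest inhibitor of the four. No measurement offered here accounts for this rise. The compounds shown leave open how much of the step belongs to the hydroxy group itself and how much to where it sits on the ring. They also leave open whether an amine or a carboxylic acid in its place would give a similar number.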